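A few compounds are considered here, and "the series" means these few. Any claim that something is new, unique, unknown or untested is made for them only; others in the source may bear on it.

Compound 1 `Clc1ccc(-c2nnc(COc3ccc(-c4ccccc4)cc3)o2)c(Cl)c1` gives 57.6% in a functional assay on the whole organism (strain Wistar) for inhibition, with Rattus norvegicus as the target, read by paw edema, with a stated time of 4 h, at a dose of 10 mg/kg by the oral route; on this read-out higher numbers stand for more inhibition at the one dose given (going by the name of the read-out) and lower numbers for less inhibition.
Compound 2 `CC(C)Cc1ccc(C(C)c2nnc(COc3ccc(-c4ccccc4)cc3)o2)cc1` gives 79.5%.
Compound 3 `CCCCNc1nnc(COc2ccc(-c3ccccc3)cc2)s1` gives 27.3%.

Compound 3 stands lowest of the three numbers: compound 1 is nearest, higher by a gap beyond the usual scatter, and compound 2 is furthest, also beyond the scatter. Compound 4 `Cc1ccccc1Nc1nnc(COc2ccc(-c3ccccc3)cc2)s1` differs from compound 3 in one place: 2-methylphenyl in place of butyl on a nitrogen on an aromatic ring. Among the measured compounds shown here, no pair of measured compounds carries this change alone, so its size is uncertain; compounds 1 and 2 both bear aromatic rings and sit higher than compound 3, but each differs from it in more than one place. A rise of moderate size, beyond the scatter, is expected: a number 14.7 percentage points higher from compound 3 to compound 4 (beyond the scatter). Compound 4 is therefore estimated at 42%, between 22% and 62%.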

Compound 4, a percentage reported as inhibition, in the whole organism at one dose (the size of the read-out at that dose, not a potency): 29.5%
For compound 4 the middle estimate is 12.5 percentage points above the measured one, and the stated range covers the measured number.
By their numbers in this assay, from the lowest: compounds 3 and 4 (each within the scatter of the next); then compound 1; then compound 2.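

Replacing butyl with 2-methylphenyl on a nitrogen on an aromatic ring gives a number 2.2 percentage points higher from compound 3 to compound 4 (within the scatter) in this assay, the only single-place step shown in the series. At this position, the open chain and the methyl-bearing aromatic ring cannot be told apart on this read-out. Nothing measured here bears on why the two read alike.

Open, from the compounds shown here alone, is whether unsubstituted phenyl, a longer chain such as octyl, or a carboxylic acid on the ring would separate from these two groups. Compounds 1 and 2 differ from both in more than one place, so their higher numbers cannot be assigned to this position.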